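Oral exposure notes: aryl substituent swap on the shared core

The compounds below may be only part of what the source reports. "The series", "measured", "known", "first", "only" and "open" are said of these compounds alone.

Measured so far:
compound 1 `CC(C)(C)S(=O)(=O)Nc1ccc(-c2c(C(N)=O)c3cc(F)c(OC(F)F)cc3n2-c2ccccc2)cc1` — 7670 ng.h/mL
compound 2 `CC(C)(C)S(=O)(=O)Nc1ccc(-c2c(C(N)=O)c3cc(F)c(OC(F)F)cc3n2C2CCCC2)cc1` — 200 ng.h/mL

In an ADME assay on the whole organism (plasma, strain Sprague-Dawley) for pharmacokinetics, with Rattus norvegicus as the target, with stated times of 6 h and 30 min, at a dose of 10 mg/kg by the oral route (on this read-out higher numbers stand for higher exposure at the dose given and lower numbers for lower exposure), compound 1 gives 7670 ng.h/mL, the highest of the two numbers in hand. The nearest is compound 2, which gives 200 ng.h/mL. Within the data shown here, that gap is the only measured step, a 38-fold lower number from compound 1 to compound 2 (1.58 log units; beyond the scatter), and it comes from cyclopentyl in place of phenyl on an aromatic nitrogen.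

Compound 3 `Cc1cc2c(cc1F)c(C(N)=O)c(-c1ccc(NS(=O)(=O)C(C)(C)C)cc1)n2-c1ccccc1` differs from compound 1 at a different position: methyl in place of difluoromethoxy on an aromatic carbon. Among the measured compounds shown here, no measured pair touches this position or this kind of exchange. For the measured compounds named here, the one step available, a 38-fold lower number from compound 1 to compound 2 (1.58 log units; beyond the scatter), concerns the group on the aromatic nitrogen and so offers no direct guide to a change on the six-membered carbon ring of the fused system. With nothing to lean on, the working expectation for compound 3 is a step no larger than the scatter, a 1.5-fold lower number from compound 1 to compound 3 (0.19 log units; within the scatter), carrying wide uncertainty in either direction. Compound 3 is therefore estimated at 5000 ng.h/mL, expected to fall between 1500 ng.h/mL and 15000 ng.h/mL.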

Compound 3, area under the concentration-time curve: 7140 ng.h/mL
Compound 3: middle estimate off by 1.4-fold (0.15 log units), on the low side, within the range that was stated.
By their numbers in this assay, from the lowest: compound 2; then compounds 3 and 1 (each within the scatter of the next).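

Placing methyl in place of difluoromethoxy on the aromatic carbon ortho to a fluoro group gives a 1.1-fold lower number from compound 1 to compound 3 (0.03 log units; within the scatter) in this assay, so this exchange leaves oral exposure unchanged within the scatter, even though the group goes from 4 heavy atoms to 1 heavy atom and from 1 hydrogen-bond acceptor to 0 hydrogen-bond acceptors. The two single changes around compound 1 therefore read very differently: the change on the aromatic nitrogen gives a 38-fold lower number from compound 1 to compound 2 (1.58 log units; beyond the scatter), which is beyond the scatter, while the change on the six-membered aromatic ring does not move the number beyond the scatter. No supporting measurement accounts for the flat result at this position, so the data show the size of the step and nothing of its cause.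

As far as these compounds go, it remains open whether this position would stay as flat with an amine, a carboxylic acid or a longer alkoxy chain on the same aromatic carbon. From the compounds shown here alone, it is also open whether methyl and difluoromethoxy would still match when cyclopentyl, rather than phenyl, sits on the aromatic nitrogen.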